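Replacing the Phenyl Ring in the Cyclohexyl Sulfonylurea

A few compounds are considered here, and "the series" means these few. Any claim that something is new, unique, unknown or untested is made for them only; others in the source may bear on it.

Measured so far:
compound 1 `CCCNC(=O)NS(=O)(=O)c1ccc(-n2nc(-c3ccccc3)ccc2=O)cc1` gives 125%
compound 2 `CCCCNC(=O)NS(=O)(=O)c1ccc(-n2nc(-c3ccccc3)ccc2=O)cc1` gives 111%
compound 3 `O=C(NC1CCCCC1)NS(=O)(=O)c1ccc(-n2nc(-c3ccccc3)ccc2=O)cc1` gives 86.2%

All three were tested in a functional assay on the whole organism (blood, strain Wistar albino) for inhibition, with Rattus norvegicus as the target, read by colorimetric assay, with stated times of 15 min and 90 min, at a dose of 20 mg/kg by the oral route; on this read-out higher numbers stand for more inhibition at the one dose given (going by the name of the read-out) and lower numbers for less inhibition. Compound 3 stands lowest of the three numbers: the nearest is compound 2, and the step of a number 24.8 percentage points lower from compound 2 to compound 3 (beyond the scatter) is beyond the scatter; the furthest is compound 1, and the step of a number 38.8 percentage points lower from compound 1 to compound 3 (beyond the scatter) is beyond the scatter as well. The remaining step, a number 14 percentage points lower from compound 1 to compound 2 (beyond the scatter), also concerns only the group on the amide-type nitrogen.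

Compound 4 `Cc1cc(-c2ccc(=O)n(-c3ccc(S(=O)(=O)NC(=O)NC4CCCCC4)cc3)n2)ccc1Cl` keeps the cyclohexyl of compound 3 and alters the far end of the shared core instead: 4-chloro-3-methylphenyl in place of phenyl on an aromatic carbon.

Among the compounds with values here, none of the measured steps touches that ring; each of them changes the group on the amide-type nitrogen. The data therefore give no direct guide to the size or direction of this change, and the plain expectation is a step that stays within the scatter, so that compound 4 is expected to sit near compound 3, with a number 1.2 percentage points lower from compound 3 to compound 4 (within the scatter). The estimate for compound 4 in this assay is 85%, with a range from 60% to 110%.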

Compound 4, a percentage reported as inhibition, in the whole organism at one dose (the size of the read-out at that dose, not a potency): 55.2%
Compound 4: the middle estimate sits 29.8 percentage points above what was measured; the whole stated range lies above it.
By their numbers in this assay, from the lowest: compound 4; then compound 3; then compound 2; then compound 1.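

The far end of the shared core matters in this assay: with the cyclohexyl on the amide-type nitrogen held fixed, 4-chloro-3-methylphenyl in place of phenyl gives a number 31 percentage points lower from compound 3 to compound 4 (beyond the scatter). Within the data shown here, all the earlier compounds carry the plain phenyl, so they could speak only about the group on the amide-type nitrogen, whereas this step shows that a change on the ring can count for as much as the large change there, a number 38.8 percentage points lower from compound 1 to compound 3 (beyond the scatter). No measurement shown here bears on why the number falls at this position.

The new group brings two additions at once, a chlorine and a methyl, so the compounds shown cannot say whether one of them accounts for the step or both are needed; 4-chlorophenyl and 3-methylphenyl, each on its own, would separate the two. On these data alone, it also stays open whether the same ring change would lower the number by a similar amount with the propyl of compound 1 on the amide-type nitrogen, and how a methoxy group on this ring would compare.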